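The compounds below may be only part of what the source reports. "The series", "measured", "known", "first", "only" and "open" are said of these compounds alone.

Measured so far:
Compound 1, `Cc1nc(C(=O)Nc2ccc(Cl)c(-c3nnc4c(Cl)cccn34)c2)cs1`, in a functional assay on MDA-MB-231 cells (Homo sapiens) for antiproliferative activity, read by MTT assay, with stated times of 72 h and 4 h; a higher number here means a weaker inhibitor, a lower number a stronger inhibitor: > 100000 nM, a limit of the assay.
Compound 2, `O=C(Nc1ccc(Cl)c(-c2nnc3c(Cl)cccn23)c1)c1ccccc1Cl`, in this assay: 59900 nM.
Compound 3, `O=C(Nc1ccc(Cl)c(-c2nnc3c(Cl)cccn23)c1)c1ccc(Cl)cc1Cl`, in this assay: > 100000 nM, again a limit of the assay.

Compound 3 therefore stands only as a limit, not as a number, and it shares that position with compound 1 (the limit of > 100000 nM in this assay, at which 2 of the 3 values shown sit). Among the compounds with values here, the one step into compound 3 that can be read is an at least 1.6-fold higher number from compound 2 to compound 3 (0.22 log units; that floor lies within the scatter), and even that is only a floor within the scatter; the step that the two limits leave unreadable from compound 1 to compound 3 cannot be read at all.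

Compound 4, `O=C(Nc1ccc(Cl)c(-c2nnc3c(Cl)cccn23)c1)c1cccnc1`, is not yet measured. It differs from compound 3 by pyridin-3-yl in place of 2,4-dichlorophenyl on a carbonyl carbon. Within the data shown here, no measured step exchanges a dichlorophenyl for a pyridinyl, so the nearest guide is the move between a small heteroaryl and a chlorophenyl, an at least 1.6-fold lower number from compound 1 to compound 2 (0.22 log units; that floor lies within the scatter), whose floor also lies within the scatter. Compound 1, the heteroaryl amide, sits at the limit; compound 2, the chlorophenyl amide, barely leaves it. Among the measured compounds shown here, the account expects compound 4 to behave like compound 1 and to show a number no higher from compound 3 to compound 4 (the limit leaves the size open), that is, no step readable beyond the scatter. The estimate for compound 4 in this assay is 100000 nM, within 40000 nM to 300000 nM.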

Compound 4, half-maximal inhibitory concentration: > 100000 nM
Compound 4 ended at the assay's limit; the forecaster's own chance of this, stated with the estimate: 60%; the middle value lies on the limit itself.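

Exchanging the 2,4-dichlorophenyl for the pyridin-3-yl on this carbonyl carbon brings a ring with a hetero atom and a hydrogen-bond acceptor, yet it yields no readable number in this assay; the steps to compound 4 from compound 3 and from compound 1 cannot be read, as both ends of each are limits. The only step that can be read is an at least 1.6-fold higher number from compound 2 to compound 4 (0.22 log units; that floor lies within the scatter), which leaves compound 2 as the one compound of the four with a number and the one that goes against the pattern, although its separation from the others is never shown beyond the scatter. The 2-methyl-1,3-thiazol-4-yl, the 2,4-dichlorophenyl and the pyridin-3-yl thus all end in the same position: the limit of > 100000 nM in this assay, at which 3 of the 4 values shown sit.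

The compounds shown leave open whether any group on this carbonyl carbon, such as a saturated amine like piperidine or a phenyl carrying a carboxylic acid, can give a number clearly clear of the limit in this assay. Every compound shown also keeps the shared core unchanged, so the result of replacing a chloro there with a methoxy remains open.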